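The compounds below may be only part of what the source reports. "The series", "measured", "known", "first", "only" and "open" are said of these compounds alone.

Working notes on the series. Compound 1 (`CC(C)COc1ncc(-c2cn(C)c3cc(C(=O)NS(C)(=O)=O)ccc23)cc1Cl`) and compound 2 (`CC(C)Cc1ccc(-c2cn(C)c3cc(C(=O)NS(C)(=O)=O)ccc23)cc1`) were both tested in an ADME assay on Caco-2 cells (Homo sapiens) for permeability, in the apical to basolateral direction; a higher number here means that the compound crosses the layer faster, a lower number that the compound crosses the layer more slowly. Compound 1 gives < 15 nm/s, which is a limit of the assay and not a number. Going by these compounds, compound 2 also gives only a limit, < 15 nm/s, so its true position is unknown. For the measured compounds named here, the series so far reads (the limit of < 15 nm/s in this assay, at which 2 of the 2 values shown sit), and no measured step is available to size a change.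

Compound 3 (`Cn1cc(-c2ccc(C(F)(F)F)cc2)c2ccc(C(=O)NS(C)(=O)=O)cc21`) carries trifluoromethyl in place of isobutyl on an aromatic carbon, para to a large group, (trifluoromethyl in place of isobutyl on an aromatic carbon). The expected change, a step that the limit leaves unreadable from compound 2 to compound 3, is estimated to stay within the usual scatter, with no direction favoured. Compound 3 is expected at 13 nm/s, with an estimated range of 5 nm/s to 30 nm/s, and a report of only a limit is the likelier outcome.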

Compound 3, apparent permeability: < 15 nm/s
Compound 3: only a limit was reported; the forecaster's own chance of this, stated with the estimate: 70%; the middle value lies beyond the limit too.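

In this assay compound 3 gives < 15 nm/s, a limit of the assay and not a number. No step can be read between compound 2 and compound 3, and the series stands at: the limit of < 15 nm/s in this assay, at which 3 of the 3 values shown sit. The compounds shown leave open where the true values of compounds 1, 2 and 3 lie, and whether trifluoromethyl and isobutyl differ at all here.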